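Adding a Methoxy Next to the Methylpiperazine Arm

A few compounds are considered here, and "the series" means these few. Any claim that something is new, unique, unknown or untested is made for them only; others in the source may bear on it.

Compound 1 `C=CC(=O)N1CC[C@H](N2C(=O)N(c3ccccc3)Cc3cnc(Nc4ccc(N5CCN(C)CC5)cc4)nc32)C1` is one of three related compounds that have been measured in an ADME assay on the whole organism (strain Sprague-Dawley) for pharmacokinetics, with Rattus norvegicus as the target, read by LC-MS, at a dose of 25 mg/kg by the oral route; a lower number here means less compound in the circulation, a higher number more compound in the circulation at the dose given. In this assay compound 1 gives 1450 nM, the second highest of the three numbers. Compound 2 `C=CC(=O)N1CC[C@H](N2C(=O)N(c3ccccc3)Cc3cnc(Nc4ccc(N5CCN(C)CC5)cc4OC)nc32)C1` gives 1080 nM, and compound 3 `C=CC(=O)N1CC[C@H](N2C(=O)N(c3ccccc3)Cc3cnc(Nc4ccccc4)nc32)C1` gives 3800 nM.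

Two single-point changes from compound 1 have been measured. The first, a 1.3-fold lower number from compound 1 to compound 2 (0.13 log units; within the scatter), came from a methoxy in place of hydrogen on an aromatic carbon. Among the compounds with values here, the second, a 2.6-fold higher number from compound 1 to compound 3 (0.42 log units; beyond the scatter), came from a hydrogen in place of 4-methylpiperazin-1-yl on an aromatic carbon, and stands out as the only change beyond the scatter.

Compound 4 `C=CC(=O)N1CC[C@H](N2C(=O)N(c3ccccc3)Cc3cnc(Nc4ccc(N5CCN(C)CC5)c(OC)c4)nc32)C1` has not been measured. Compared with compound 1 it carries methoxy in place of hydrogen on an aromatic carbon. The step that bears most directly on it is a 1.3-fold lower number from compound 1 to compound 2 (0.13 log units; within the scatter), since that too introduced a methoxy and stayed within the scatter; the 4-methylpiperazin-1-yl group, whose removal in compound 3 raised the number, is kept in compound 4.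

On that basis the expected step from compound 1 to compound 4 is a 1.1-fold lower number from compound 1 to compound 4 (0.05 log units; within the scatter), meaning no change beyond the scatter. Compound 4 is therefore estimated to give 1300 nM, in a range from 600 nM to 2800 nM.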

Compound 4, maximal plasma concentration: 739 nM
Compound 4: middle estimate off by 1.8-fold (0.25 log units), on the high side; low and high end bracket the measured number.
By their numbers in this assay, from the lowest: compounds 4, 2 and 1 (each within the scatter of the next); then compound 3.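

In this assay, a methoxy on an aromatic carbon ortho to a 4-methylpiperazin-1-yl group gives a 2.0-fold lower number from compound 1 to compound 4 (0.29 log units; within the scatter), so this second place on the same aromatic ring also takes the new group without a change that can be told from the scatter. The earlier step, a 1.3-fold lower number from compound 1 to compound 2 (0.13 log units; within the scatter), had shown this for one methoxy placement only; compound 2 and compound 4 now sit within the scatter of each other, and this read-out does not separate the two placements. No measurement at hand bears on what lies behind the number for compound 4.

The compounds shown leave open whether this place would accept other groups as readily, such as a fluorine atom, a hydroxyl, or a longer chain like ethoxy. They also leave open what a methoxy would do here on a compound without the 4-methylpiperazin-1-yl group, and what a second methoxy would do on compound 2.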